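A few compounds are considered here, and "the series" means these few. Any claim that something is new, unique, unknown or untested is made for them only; others in the source may bear on it.

Working notes on the series, read in a functional assay for inhibition, with Rattus norvegicus as the target; on this read-out lower numbers stand for stronger inhibition and higher numbers for weaker inhibition. Compound 1 `CC(/N=c1\c(O)c(O)\c1=N/c1cncc(Br)c1)C(C)(C)C` gives 11700 nM and compound 3 `CC(/N=c1\c(O)c(O)\c1=N/c1ccccc1)C(C)(C)C` gives 5400 nM, the lower of the two actual numbers. Compound 2 `CC(C)(C)/N=c1\c(O)c(O)\c1=N/c1ccc2ncccc2c1` returns only a limit, > 30000 nM, so it cannot be placed against the others.

Compound 4 `CC(/N=c1\c(O)c(O)\c1=N/c1ccc(S(N)(=O)=O)cc1)C(C)(C)C` departs from compound 3 by one change, sulfamoyl in place of hydrogen on an aromatic carbon, para to a large group: sulfamoyl in place of hydrogen on an aromatic carbon.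

Among the compounds with values here, only one measured step bears on this, a 2.2-fold lower number from compound 1 to compound 3 (0.34 log units; beyond the scatter), with phenyl in place of 5-bromopyridin-3-yl on a double-bonded nitrogen. It concerns the same double-bonded nitrogen substituent but does not involve sulfamoyl, so it offers a scale rather than a precedent. A modest step of similar size is therefore expected in this assay, with only a weak lean towards a lower number. The expected change is a 2.2-fold lower number from compound 3 to compound 4 (0.33 log units; beyond the scatter). Compound 4 is estimated at 2500 nM, with an expected range from 500 nM to 13000 nM.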

Compound 4, half-maximal inhibitory concentration: > 30000 nM
Compound 4: no number, only a limit; the forecaster's own chance of this, stated with the estimate: 10%; middle value at least 12-fold (1.07 log units) away from the limit.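

In this assay compound 4 gives > 30000 nM, which is a limit of the assay and not a number. The step of an at least 5.5-fold higher number from compound 3 to compound 4 (0.74 log units; beyond the scatter) shows that sulfamoyl in place of hydrogen on an aromatic carbon, para to a large group, moves the read-out towards weaker inhibition, and this is the first change shown on the carbon-only ring of compound 3 itself. The full size of that step stays unread because the read-out ends at a limit: the limit of > 30000 nM in this assay, at which 2 of the 4 values shown sit.

As far as these compounds go, whether the shift belongs to sulfamoyl specifically or to any added group at this place stays open, and an amine or a carboxylic acid in the same place would speak to that. Also open, from the compounds shown here alone, is whether sulfamoyl elsewhere on the ring would give the same result.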